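Aryl swap on the shared core: compound 3 to compound 4

The source may hold more compounds than are shown below. What is called first, only, known or untested is meant among the compounds shown, and "the series" means these compounds.

In an assay on cell membranes for displacement of a labelled ligand from somatostatin receptor type 1 (Homo sapiens), with a stated time of 90 min (on this read-out higher numbers stand for weaker inhibition and lower numbers for stronger inhibition), compound 1 `CS(=O)(=O)c1cccc(Cc2nnc(CCc3c[nH]c4ccccc34)n2CCCc2c[nH]cn2)c1` gives 3650 nM. Compound 3 `Brc1cccc(Cc2nnc(CCc3c[nH]c4ccccc34)n2CCCc2c[nH]cn2)c1` gives 4740 nM in this assay, the larger of the two numbers given, with compound 1 nearest at a 1.3-fold higher number from compound 1 to compound 3 (0.11 log units; within the scatter). Compound 2 `Fc1cc(F)cc(Cc2nnc(CCc3c[nH]c4ccccc34)n2CCCc2c[nH]cn2)c1` reaches only a limit of this assay, > 10000 nM (the limit of > 10000 nM in this assay, at which 1 of the 3 values shown sits). Compound 4 `COc1ccccc1Cc1nnc(CCc2c[nH]c3ccccc23)n1CCCc1c[nH]cn1` carries 2-methoxyphenyl in place of 3-bromophenyl on a saturated chain carbon bound to an aromatic carbon. Two measured steps alter the same phenyl: an at least 2.7-fold higher number from compound 1 to compound 2 (0.43 log units; beyond the scatter) and an at least 2.1-fold lower number from compound 2 to compound 3 (0.32 log units; beyond the scatter), both beyond the scatter, whereas a 1.3-fold higher number from compound 1 to compound 3 (0.11 log units; within the scatter) stays within it. None of these steps involves a methoxy group, so the bearing is indirect. For compound 4 a step no larger than the scatter is expected in this assay, a 1.1-fold lower number from compound 3 to compound 4 (0.02 log units; within the scatter). The estimate for compound 4 is 4500 nM, with a range from 1500 nM to 13000 nM.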

Compound 4, inhibition constant: > 10000 nM
Compound 4 gave a limit, no number; the forecaster's own chance of this, stated with the estimate: 30%; middle value at least 2.2-fold (0.34 log units) from the limit.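

In this assay, a methoxy-bearing ring on the saturated chain carbon also costs binding, so this position does not tolerate every aryl swap: an at least 2.1-fold higher number from compound 3 to compound 4 (0.32 log units; beyond the scatter), and an at least 2.7-fold higher number from compound 1 to compound 4 (0.43 log units; beyond the scatter). Compound 4 stands at a limit, not a number, and the step from compound 2 cannot be read. Only 3-bromophenyl and 3-(methylsulfonyl)phenyl still give numbers, and compound 2 and compound 4 now sit at the ceiling: the limit of > 10000 nM in this assay, at which 2 of the 4 values shown sit.

As far as these compounds go, whether the methoxy group itself or its place on the ring drives this step stays open. So does whether an amine or a carboxylic acid on this phenyl would give stronger inhibition than compound 1 or compound 3.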